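Swapping Bromo for Methoxycarbonyl: Expected Solubility Shift

The source may report more compounds than this note shows. Statements on the series, on what has been measured and on what is new or still open speak of the compounds shown alone.

Three compounds share one core and differ only in the group carried on one phenyl ring. In a physicochemical assay for solubility, read by spectrophotometry, in phosphate buffer, with a stated time of 18 h, at pH 7.4 (a lower number here means a less soluble compound, a higher number a more soluble compound), compound 1 `CCc1ccc(-c2nc3c(c(C)nn3-c3ccccc3)c(-c3ccccc3C#N)c2C#N)cc1` gives 2400 nM, compound 2 `CCc1ccc(-c2nc3c(c(C)nn3-c3ccccc3)c(-c3ccccc3Br)c2C#N)cc1` gives 1500 nM, and compound 3 `CCc1ccc(-c2nc3c(c(C)nn3-c3ccccc3)c(-c3ccc(O)cc3)c2C#N)cc1` gives 5700 nM. Compound 2 has the lowest of the three numbers; the step of a 1.6-fold lower number from compound 1 to compound 2 (0.20 log units; within the scatter) stays within the scatter, while a 3.8-fold higher number from compound 2 to compound 3 (0.58 log units; beyond the scatter) and a 2.4-fold higher number from compound 1 to compound 3 (0.38 log units; beyond the scatter) are modest.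

Compound 4 `CCc1ccc(-c2nc3c(c(C)nn3-c3ccccc3)c(-c3ccccc3C(=O)OC)c2C#N)cc1` differs from compound 2 by a single change: methoxycarbonyl in place of bromo on an aromatic carbon. Going by the values given here, no measured step replaces bromo with methoxycarbonyl. The closest guide is a 1.6-fold lower number from compound 1 to compound 2 (0.20 log units; within the scatter), where exchanging one small group on an aromatic carbon for another left the number within the scatter. The larger change to 4-hydroxyphenyl, a 3.8-fold higher number from compound 2 to compound 3 (0.58 log units; beyond the scatter), was modest. A small rise is therefore expected for compound 4, a 1.7-fold higher number from compound 2 to compound 4 (0.22 log units; within the scatter), near the edge of the scatter. Compound 4 is estimated at 2500 nM in this assay, with a range of 1000 nM to 6000 nM.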

Compound 4, solubility: 17000 nM
The estimate for compound 4 lay 6.8-fold (0.83 log units) below the measured number; the measured number lies above the stated range.
By their numbers in this assay, from the lowest: compounds 2 and 1 (each within the scatter of the next); then compound 3; then compound 4.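

In this assay, going by these compounds alone, this position on the phenyl ring turns out to be far more responsive than the earlier compounds suggested: methoxycarbonyl in place of bromo gives an 11-fold higher number from compound 2 to compound 4 (1.05 log units; beyond the scatter), and methoxycarbonyl in place of cyano gives a 7.1-fold higher number from compound 1 to compound 4 (0.85 log units; beyond the scatter), although bromo and cyano themselves lie within the scatter of each other. The 2-(methoxycarbonyl)phenyl group also surpasses the 4-hydroxyphenyl group, with a 3.0-fold higher number from compound 3 to compound 4 (0.47 log units; beyond the scatter), so the highest number of the four now belongs to compound 4. Nothing available here explains the rise.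

The compounds shown do not tell whether the gain depends on the carbonyl alone or on the whole methyl ester, a question that a carboxylic acid or a primary amide at this place could help to separate. They also leave open whether a longer ester, such as ethoxycarbonyl, would give a similar number.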